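The source may hold more compounds than are shown below. What is called first, only, known or untested is meant among the compounds shown, and "the series" means these compounds.

Series notes, measured in a functional assay (Homo sapiens) for antiproliferative activity; a lower number here means a stronger inhibitor of growth, a higher number a weaker inhibitor of growth:

- compound 1 `Cc1cn2c(/C=N/NC(=N)N)c(-c3ccncc3)nc2s1`: 28200 nM
- compound 2 `N=C(N)N/N=C/c1c(-c2cccnc2)nc2sc(Cl)cn12`: 42700 nM

Only these two values are available so far. In this assay, compound 2 gives 42700 nM, which lies within the scatter of compound 1 at 28200 nM. Neither compound can therefore be ranked above the other, and both sit in the same weak range of the read-out.

The next compound to be measured is compound 3 `N=C(N)N/N=C/c1c(-c2ccncc2)nc2sc(Cl)cn12`. It differs from compound 2 by one change: pyridin-4-yl in place of pyridin-3-yl on an aromatic carbon. In words, pyridin-4-yl stands in place of pyridin-3-yl on an aromatic carbon of the shared core.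

Going by the values given here, no measured step isolates this swap. The nearest guide is compound 1, which also carries pyridin-4-yl and gives 28200 nM. That value gives no reason to expect a large move. The expected change, a 1.2-fold lower number from compound 2 to compound 3 (0.09 log units; within the scatter), is estimated to stay within the scatter, so no clear direction is expected. For compound 3 the estimated value is 35000 nM, with an expected range from 15000 nM to 75000 nM.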

Compound 3, concentration for total growth inhibition: 11700 nM
The estimate for compound 3 lay 3.0-fold (0.48 log units) above the measured number; measured number outside the range, below it.
By their numbers in this assay, from the lowest: compound 3; then compounds 1 and 2 (each within the scatter of the next).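

In this assay, pyridin-4-yl in place of pyridin-3-yl on an aromatic carbon of the shared core gives a 3.6-fold lower number from compound 2 to compound 3 (0.56 log units; beyond the scatter), so with the same atoms joined differently, the attachment of the pyridine ring alone is enough to shift the read-out beyond the scatter. With pyridin-4-yl held constant, chloro in place of methyl on an aromatic carbon gives a 2.4-fold lower number from compound 1 to compound 3 (0.38 log units; beyond the scatter), so a second place on the core also registers a single change, which compounds 1 and 2 could not show while they differed in two places. Both steps are modest and point to compound 3 as the lowest number of the three, but no measurement on hand accounts for either step.

From the compounds shown here alone, each step rests on a single pair, so it remains open whether the pyridin-4-yl advantage also holds with methyl on the core. Going by these compounds, it is equally open how pyridin-2-yl or a plain phenyl would compare at this position, and how bromo or trifluoromethyl would compare with chloro.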